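A few compounds are considered here, and "the series" means these few. Any claim that something is new, unique, unknown or untested is made for them only; others in the source may bear on it.

Measured in a functional assay on A2780 cells (Homo sapiens) for antiproliferative activity, read by resazurin assay, with a stated time of 72 h; on this read-out higher numbers stand for weaker inhibition and lower numbers for stronger inhibition:
- Compound 1 `CN(Cc1ccccc1Br)C(=O)c1cc2c(Cc3ccccc3)n[nH]c2cc1O`: 1200 nM
- Compound 2 `Cc1cccc(Cc2n[nH]c3cc(O)c(C(=O)NCc4ccccc4)cc23)c1`: > 10000 nM, a limit of the assay
- Compound 3 `Cc1cccc(Cc2n[nH]c3cc(O)c(C(=O)N(C)Cc4ccccc4Br)cc23)c1`: 310 nM

Compound 3 holds the lower of the two exact numbers. Compound 4 `COc1ccc(CN(C)C(=O)c2cc3c(Cc4cccc(C)c4)n[nH]c3cc2O)cc1` changes one group of compound 3: 4-methoxyphenyl in place of 2-bromophenyl on a saturated chain carbon bound to an amide-type nitrogen. In words, 2-bromobenzyl becomes 4-methoxybenzyl.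

The step that bears most directly is an at least 32-fold lower number from compound 2 to compound 3 (1.50 log units; beyond the scatter), which is large and arose on this same amide side. The other step, a 3.9-fold lower number from compound 1 to compound 3 (0.59 log units; beyond the scatter), is modest and lies elsewhere in the molecule, so it bears little. Within the data shown here, no measured compound carries the 4-methoxyphenyl group.

Part of the gain seen in compound 3 an at least 32-fold lower number from compound 2 to compound 3 (1.50 log units; beyond the scatter) may therefore be lost, and a moderately higher number is expected in this assay, meaning weaker inhibition. The expected change is a 3.9-fold higher number from compound 3 to compound 4 (0.59 log units; beyond the scatter). For compound 4 the estimated value is 1200 nM, with an expected range of 300 nM to 5000 nM.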

Compound 4, half-maximal inhibitory concentration: 540 nM
Estimate against measurement, compound 4: 2.2-fold (0.35 log units) above; the measured number falls inside the stated range.
By their numbers in this assay, from the lowest: compounds 3 and 4 (each within the scatter of the next); then compound 1. At a limit, above all of these: compound 2.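

In this assay, a 1.7-fold higher number from compound 3 to compound 4 (0.24 log units; within the scatter) shows that this place on the amide side accepts 4-methoxyphenyl as well as 2-bromophenyl, with no change beyond the scatter. So the bromine of compound 3 is not needed for activity here, which the earlier compounds could not show, since none of them replaced the 2-bromophenyl group while keeping the rest of compound 3. No measurement shown gives a reason for this result.

The compounds shown leave open how wide this tolerance is. A plain benzyl on the same amide nitrogen, or a benzyl ring carrying an amine or a carboxylic acid, would help to answer that.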